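The compounds below may be only part of what the source reports. "The series", "measured", "known", "first", "only" and "open" are said of these compounds alone.

Measured so far in a functional assay on MCF7 cells (Homo sapiens) for antiproliferative activity, read by CCK-8 assay, with a stated time of 72 h; a lower number here means a stronger inhibitor, a higher number a weaker inhibitor:
- compound 1 `Cc1cc(Nc2cc(N3CCN(C)CC3)nc(Nc3ccc(S(N)(=O)=O)cc3)n2)n[nH]1`: 2680 nM
- compound 2 `Cc1cc(Nc2cc(N3CCN(C)CC3)nc(Nc3ccc(C#N)cc3)n2)n[nH]1`: 372 nM

Compound 2, at 372 nM, holds the lower of the two numbers, and the gap to compound 1 lies beyond the scatter. The next entry is compound 3 `COc1ccc(Nc2nc(Nc3cc(C)[nH]n3)cc(N3CCN(C)CC3)n2)cc1`, which carries methoxy in place of cyano on an aromatic carbon, para to a large group: methoxy in place of cyano on an aromatic carbon. The shared core and the remaining groups stay the same.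

For the measured compounds named here, only one measured step bears on this change: a 7.2-fold lower number from compound 1 to compound 2 (0.86 log units; beyond the scatter). It is modest in size, beyond the scatter, and also a swap of one group on an aromatic carbon. Going by the values given here, it shows that the number in this assay can respond to such a swap, but no methoxy compound has been measured, so the direction rests on little. With compound 2 at the low end of the range seen so far, 372 nM, a move upward is the more likely outcome.

The expected step is a 2.4-fold higher number from compound 2 to compound 3 (0.38 log units; beyond the scatter), modest and toward a higher number. For compound 3 the estimated value is 900 nM, with an expected range of 250 nM to 3000 nM.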

Compound 3, half-maximal inhibitory concentration: 2750 nM
Compound 3: the middle estimate sits 3.1-fold (0.49 log units) below what was measured, within the range that was stated.
By their numbers in this assay, from the lowest: compound 2; then compounds 1 and 3 (each within the scatter of the next).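

Changing the group at this place can raise the number as well as lower it in this assay: a 7.4-fold higher number from compound 2 to compound 3 (0.87 log units; beyond the scatter), about the same size as the earlier sulfamoyl-to-cyano step but in the opposite direction. With a 1.0-fold higher number from compound 1 to compound 3 (0.01 log units; within the scatter), methoxy and sulfamoyl cannot be told apart, although they are different groups, so among these three compounds only compound 2, with cyano on the aromatic carbon para to a large group, stands apart from the others. The earlier pair alone could not show whether that gap reflected something particular to cyano or to sulfamoyl, and the data now place the lower number with cyano, though nothing measured here accounts for it.

The compounds shown leave open whether the lower number is particular to cyano or would also appear with another group at this place, such as chloro, acetyl or a carboxylic acid, any of which could fall with compound 2 or with compounds 1 and 3. They also leave open whether the swap from cyano to methoxy would give a step of similar size with a different group elsewhere on the shared core.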